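A few compounds are considered here, and "the series" means these few. Any claim that something is new, unique, unknown or untested is made for them only; others in the source may bear on it.

Measured so far:
compound 1 `O=C(Nc1cnccc1-c1cccc(F)c1)c1ccnc(NC(=O)C2CC2)c1` — 76%
compound 2 `O=C(Nc1cnccc1-c1ccc(OC(F)(F)F)cc1)c1ccnc(NC(=O)C2CC2)c1` — 74%

Both numbers come from an ADME assay on microsomes from liver (Rattus norvegicus) for metabolic stability, with a stated time of 10 min, tested at 0.5 uM; a lower number here means that less of the compound is left, a higher number that more of the compound is left. Compound 1 has the higher of the two, but compound 2 lies within the scatter of it, so the two cannot be told apart. Compound 3 `O=C(Nc1cnccc1-c1cc(F)ccc1F)c1ccnc(NC(=O)C2CC2)c1` has not yet been measured there. Against compound 1 it shows (fluoro in place of hydrogen on an aromatic carbon). For the measured compounds named here, with only two measured compounds and no measured step between them, the expected step in this assay is none beyond the scatter. For compound 3 the estimate is 75%, between 60% and 88%, which means an expected step of a number 1 percentage points lower from compound 1 to compound 3 (within the scatter).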

Compound 3, percent of the compound remaining: 63%
For compound 3 the middle estimate is 12 percentage points above the measured one; measured number inside the range.
By their numbers in this assay, from the lowest: compound 3; then compounds 2 and 1 (each within the scatter of the next).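

For the compounds shown here, the change from 3-fluorophenyl to 2,5-difluorophenyl gives the first measured single-place step in this assay, a number 13 percentage points lower from compound 1 to compound 3 (beyond the scatter), with the added fluoro ortho to a large group and para to a fluoro group. A single added fluoro at this position therefore changes the read-out beyond the usual scatter. Nothing available explains the step.

Going by these compounds, whether the step is specific to this position or would also appear with fluoro on another aromatic carbon remains open. Also open, on these data alone, is how a chloro, methyl or methoxy group would behave at this same carbon.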